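Diaryl pyrazole ureas and amides: cytotoxicity on myeloma cells

A few compounds are considered here, and "the series" means these few. Any claim that something is new, unique, unknown or untested is made for them only; others in the source may bear on it.

Measured so far:
- compound 1 `COc1cc(-c2nn(-c3cccc(NC(=O)c4ccc(Cl)c(C(F)(F)F)c4)c3)cc2-c2ccncc2)ccc1Cl`: > 32500 nM
- compound 2 `O=C(Nc1cccc(-n2cc(-c3ccncc3)c(-c3ccc(Cl)c(O)c3)n2)c1)Nc1cc(C(F)(F)F)cc(C(F)(F)F)c1`: > 50000 nM

In a functional assay on RPMI-8226 cells (Homo sapiens) for inhibition, read by sulforhodamine B assay, with a stated time of 48 h (a lower number here means that less compound is tolerated, a higher number that more compound is tolerated), compound 1 reaches only the limit of the assay, > 32500 nM. Compound 2 likewise returns only a limit in this assay, > 50000 nM. For the measured compounds named here, both values are limits and not numbers, so compound 2 stands on the tolerated side of both measured entries, and no finished step is available to calibrate the next change.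

Compound 3 `O=C(Nc1cccc(-n2cc(-c3ccncc3)c(-c3ccc(Cl)c(O)c3)n2)c1)Nc1cccc(C(F)(F)F)c1` follows from compound 2 by one change: hydrogen in place of trifluoromethyl on an aromatic carbon. Going by the values given here, with no measured step to lean on, the expected step is a number no higher from compound 2 to compound 3 (the limit leaves the size open), that is none beyond the scatter, and a further limit in this assay is the most probable outcome. Compound 3 is therefore expected to give about 50000 nM, with a range of 20000 nM to 100000 nM.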

Compound 3, concentration lethal to 50% of the cells: > 32500 nM
Compound 3 ended at the assay's limit; the forecaster's own chance of this, stated with the estimate: 75%; the middle value is on the limit's open side.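

For the compounds shown here, compound 2 and compound 3 both end at limits of the assay and not at numbers, so no step between them can be read. The compounds shown leave open how much compound is tolerated beyond each limit, and whether hydrogen in place of trifluoromethyl changes it at all.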